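From Ethyl Amide to Methylphenyl Amide: Expected Cytotoxicity

This account rests on a few compounds, and the source may have more. Where it says the series, first, only, none or still open, it means among the compounds named here.

Measured so far:
Compound 1 `CCNC(=O)CCc1cccc2c1B(O)OC2` gives > 100000 nM in an ADME assay on WI-38 cells (Homo sapiens) for cytotoxicity, read by MTT assay, with a stated time of 72 h; on this read-out lower numbers stand for stronger inhibition and higher numbers for weaker inhibition; this is a limit of the assay, not a number.
Compound 2 `O=C(CCc1cccc2c1B(O)OC2)Nc1ccc(F)cc1` gives 12000 nM in this assay.
Compound 3 `O=C(CCc1cccc2c1B(O)OC2)Nc1ccc(Cl)cc1` gives > 100000 nM in this assay; this too is a limit, not a number.

Compound 1 is therefore known only as a limit (the limit of > 100000 nM in this assay, at which 2 of the 3 values shown sit), with no measured number to place it. Compound 4 `Cc1ccc(NC(=O)CCc2cccc3c2B(O)OC3)cc1` differs from compound 1 in one place: 4-methylphenyl in place of ethyl on an amide-type nitrogen. Among the compounds with values here, two measured steps bear on this change, both replacing ethyl with a phenyl ring carrying a substituent on the amide-type nitrogen. One reads an at least 8.3-fold lower number from compound 1 to compound 2 (0.92 log units; beyond the scatter). The other reads a step that the two limits leave unreadable from compound 1 to compound 3. The two phenyl analogues also disagree with each other, since an at least 8.3-fold higher number from compound 2 to compound 3 (0.92 log units; beyond the scatter). The 4-methylphenyl of compound 4 thus follows a pattern that splits between a modest fall and no readable step. The expected step is an at least 2.5-fold lower number from compound 1 to compound 4 (0.39 log units; beyond the scatter), a cautious fall with wide uncertainty. Compound 4 is estimated to give 40000 nM, within a range from 8000 nM to 150000 nM, with a real chance that only a limit is reported.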

Compound 4, half-maximal inhibitory concentration: > 100000 nM
Compound 4 ended at the assay's limit; the forecaster's own chance of this, stated with the estimate: 50%; middle value at least 2.5-fold (0.39 log units) away from the limit.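

In this assay, methyl in place of fluoro on the aromatic carbon gives an at least 8.3-fold higher number from compound 2 to compound 4 (0.92 log units; beyond the scatter), so 4-methylphenyl on the amide-type nitrogen does not repeat the fall seen with the 4-fluorophenyl of compound 2. A phenyl ring on that nitrogen is therefore not enough on its own to give a measured number: compound 3 and compound 4 go against that idea, and compound 2 remains the only one of the three with a number. The steps from compound 1 and from compound 3 to compound 4 cannot be read, and most of the series now rests at a single limit that is not a number: the limit of > 100000 nM in this assay, at which 3 of the 4 values shown sit.

On these data alone, how far compound 1, compound 3 and compound 4 differ beyond that limit stays unknown. Also open, as far as these compounds go, is whether fluoro is unusual here, or whether a methoxy group or a nitrile in its place would also give a measured number.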